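A Larger Replacement Group on Compound 2

The compounds below may be only part of what the source reports. "The series", "measured", "known", "first", "only" and "open" are said of these compounds alone.

Of the compounds shown here, two have been measured in a functional assay on HCT-116 cells (Homo sapiens) for antiproliferative activity, read by MTT assay, with a stated time of 72 h; on this read-out lower numbers stand for stronger inhibition and higher numbers for weaker inhibition: compound 1 `NC(=S)N/N=C1/C=C(Nc2cccc(Cl)c2)C(Nc2cccc(Cl)c2)=NC1=O` gives 3380 nM, while compound 2 `COc1ccccc1NC1=C/C(=N/NC(N)=S)C(=O)N=C1Nc1ccccc1OC` gives 20800 nM, the higher of the two numbers. Compound 3 `COc1ccccc1NC1=C/C(=N/N=C(\N)SCc2ccccc2)C(=O)N=C1Nc1ccccc1OC` differs from compound 2 in one place: a group of 11 heavy atoms (8 carbon, 2 nitrogen, 1 sulfur; one six-membered aromatic ring of carbon only) in place of a group of 4 heavy atoms (1 carbon, 2 nitrogen, 1 sulfur; no ring), on a double-bonded nitrogen. Among the measured compounds shown here, no measured pair shows this change, so its effect is unknown. The expectation is a moderate step toward a lower number, a 2.6-fold lower number from compound 2 to compound 3 (0.41 log units; beyond the scatter), though a result within the scatter is possible. Compound 3 is therefore estimated at 8000 nM in this assay, with a range from 2500 nM to 25000 nM.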

Compound 3, half-maximal inhibitory concentration: 14500 nM
The estimate for compound 3 lay 1.8-fold (0.26 log units) below the measured number, within the range that was stated.
By their numbers in this assay, from the lowest: compound 1; then compounds 3 and 2 (each within the scatter of the next).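

On this double-bonded nitrogen, a much larger group with a six-membered aromatic ring of carbon only can replace the group of 4 heavy atoms in this assay, and the step is a 1.4-fold lower number from compound 2 to compound 3 (0.16 log units; within the scatter). Among the compounds shown here, the added bulk therefore brings no difference that can be told from the scatter, something the earlier compounds could not show. Nothing measured here explains this result.

Still open, as far as these compounds go, is whether a group carrying an amine or a carboxylic acid would give a different number in this place. From the compounds shown here alone, the same change on the core of compound 1 also remains open.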